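The compounds below may be only part of what the source reports. "The series", "measured", "known", "first", "only" and "open" are said of these compounds alone.

Measured compounds:
- compound 1, `O=C(CCCCCCCc1ccccc1)N[C@H]1CCOC1=O`: > 100000 nM in a functional assay on NCI-H630 cells (Homo sapiens) for cytotoxicity, read by sulforhodamine B assay, with a stated time of 5 days; on this read-out higher numbers stand for weaker inhibition and lower numbers for stronger inhibition
- compound 2, `O=C(CCCCCCCCCCCc1ccccc1)CC(=O)N[C@H]1CCOC1=O`: 27000 nM
- compound 3, `O=C(CCCCCCCCCCc1ccccc1)CC(=O)N[C@H]1CCOC1=O`: 14000 nM

Compound 1 is reported only as a limit of this assay, (the limit of > 100000 nM in this assay, at which 1 of the 3 values shown sits), not as a number. Compound 2 and compound 3 share one core; the difference between that core and the core of compound 1 is not broken down here. The change from compound 2 to compound 3 is phenyl in place of benzyl on a saturated chain carbon, ten or more bonds along the chain from a carbonyl carbon, and it made a 1.9-fold lower number from compound 2 to compound 3 (0.29 log units; within the scatter), so the two values are not told apart.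

The unmeasured compound 4, `O=C(CCCCCCc1ccccc1)N[C@H]1CCOC1=O`, arises from compound 1 by phenyl in place of benzyl on a saturated chain carbon, six bonds along the chain from a carbonyl carbon. Within the data shown here, this is the same kind of change as the one between compound 2 and compound 3, but not the same: the place along the chain from the carbonyl carbon differs between the two, as the two descriptions show, and the cores differ as well.

Given that the one measured instance of this kind of change stayed within the scatter, no shift of any size is expected from it here. The expectation rests on compound 1, which gives only > 100000 nM in this assay. For compound 4 the estimate is 150000 nM, most likely again reported as a limit. As a step this estimate amounts to a step that the limit leaves unreadable from compound 1 to compound 4.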

Compound 4, half-maximal inhibitory concentration: > 100000 nM
Compound 4 was reported as a limit; the forecaster's own chance of this, stated with the estimate: 80%; the middle value does not contradict the limit.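

Compound 1 and compound 4 are both reported only as limits, so no step between them can be read: the limit of > 100000 nM in this assay, at which 2 of the 4 values shown sit.

The compounds shown leave open whether phenyl in place of benzyl on a saturated chain carbon, six bonds along the chain from a carbonyl carbon, shifts the read-out at all on the core of compound 1.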